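Swapping one ring-bearing group on compound 2

The compounds below may be only part of what the source reports. "The series", "measured", "known", "first", "only" and "open" are said of these compounds alone.

Measured so far in a functional assay on A549 cells (Homo sapiens) for antiproliferative activity (on this read-out higher numbers stand for weaker inhibition of growth and lower numbers for stronger inhibition of growth), for the shared core:
compound 1 `CC/C=C\[C@H](C)[C@H](OC(N)=O)[C@@H](C)[C@H](O)[C@@H](C)C/C(C)=C\[C@H](C)[C@@H](O)[C@@H](C)/C=C\[C@@H](O)C[C@H](O)[C@H](C)CO` gives 3000 nM in growth inhibition
compound 2 `CC/C=C\[C@H](C)[C@H](OC(N)=O)[C@@H](C)[C@H](O)[C@@H](C)C/C(C)=C\[C@H](C)[C@@H](O)[C@@H](C)/C=C\[C@@H](O)C[C@@H]1OC(=O)NC[C@H]1C` gives 520 nM in growth inhibition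

Compound 2 holds the lower of the two numbers, which makes it the stronger growth inhibitor of this pair. The measured step is a 5.8-fold lower number from compound 1 to compound 2 (0.76 log units; beyond the scatter) and it lies beyond the scatter. In that step, a group with no ring gave way to one carrying a six-membered non-aromatic ring with 2 hetero atoms.

Compound 3 `CC/C=C\[C@H](C)[C@H](OC(N)=O)[C@@H](C)[C@H](O)[C@@H](C)C/C(C)=C\[C@H](C)[C@@H](O)[C@@H](C)/C=C\[C@H](O)C[C@@H]1CCC(=O)O1` has not been measured yet. It differs from compound 2 by a group of 9 heavy atoms (6 carbon, 3 oxygen; one five-membered non-aromatic ring with 1 hetero atom) in place of a group of 11 heavy atoms (7 carbon, 1 nitrogen, 3 oxygen; one six-membered non-aromatic ring with 2 hetero atoms), on a double-bonded chain carbon bound to a double-bonded chain carbon in one place. Among the compounds with values here, the single measured step compares a ring with no ring, whereas compound 3 keeps a ring of another kind. Within the data shown here, no measured step compares two rings, so the data offer only a loose guide. A small move towards weaker inhibition is expected, possibly none beyond the scatter. The estimate means a 1.3-fold higher number from compound 2 to compound 3 (0.13 log units; within the scatter) as the expected change in this assay here. For compound 3 the expected value is 700 nM with 150 nM to 3000 nM as the estimated range.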

Compound 3, concentration for 50% growth inhibition: 4000 nM
Beside the measured number, compound 3's estimate is 5.7-fold (0.76 log units) below it, outside the stated range (above it).
By their numbers in this assay, from the lowest: compound 2; then compounds 1 and 3 (each within the scatter of the next).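

In this assay, the step of a 7.7-fold higher number from compound 2 to compound 3 (0.89 log units; beyond the scatter) shows that the group on a double-bonded chain carbon bound to a double-bonded chain carbon matters by more than simply carrying a ring. The step of a 1.3-fold higher number from compound 1 to compound 3 (0.12 log units; within the scatter) lies within the scatter, so the five-membered non-aromatic ring with 1 hetero atom in compound 3 cannot be told apart from the ring-free group of compound 1, and among these three compounds only the six-membered non-aromatic ring with 2 hetero atoms in compound 2 stands out. Nothing at hand accounts for this difference between the two ring-bearing groups.

The two ring-bearing groups differ at once in ring size, in the presence of nitrogen, in their count of hydrogen-bond donors and in their defined stereocentres, so the compounds shown cannot say which of these differences goes with the step. A five-membered ring holding a nitrogen, or a six-membered ring with oxygen as its only hetero atom, would begin to pull these differences apart.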